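A Phenyl in Place of 4-(tert-butyl)-1,3-thiazol-2-yl

The source may hold more compounds than are shown below. What is called first, only, known or untested is meant among the compounds shown, and "the series" means these compounds.

In an ADME assay on MT4 cells (Homo sapiens) for cytotoxicity (a lower number here means that less compound is tolerated, a higher number that more compound is tolerated), compound 1 `COC(=O)N[C@H](C(=O)NN(CCC[C@@](O)(Cc1ccccc1)C(=O)N[C@H]1c2ccccc2C[C@H]1O)Cc1ccc(-n2ccnc2)cc1)C(C)(C)C` gives > 10000 nM, which is a limit of the assay. Compound 2 `COC(=O)N[C@H](C(=O)NN(CCC[C@@](O)(Cc1ccccc1)C(=O)N[C@H]1c2ccccc2C[C@H]1O)Cc1ccc(-c2nc(C(C)(C)C)cs2)cc1)C(C)(C)C` gives > 10000 nM, again only a limit. Among the measured compounds shown here, the one measured step is a step that the two limits leave unreadable from compound 1 to compound 2. Compound 3 `COC(=O)N[C@H](C(=O)NN(CCC[C@@](O)(Cc1ccccc1)C(=O)N[C@H]1c2ccccc2C[C@H]1O)Cc1ccc(-c2ccccc2)cc1)C(C)(C)C` differs from compound 2 by phenyl in place of 4-(tert-butyl)-1,3-thiazol-2-yl on an aromatic carbon, with phenyl in place of 4-(tert-butyl)-1,3-thiazol-2-yl on an aromatic carbon. No step beyond the scatter is expected, because of the limit of > 10000 nM in this assay, at which 2 of the 2 values shown sit. The expected change is a step that the limit leaves unreadable from compound 2 to compound 3. For compound 3 the estimate is 20000 nM, with an expected range from 10000 nM to 60000 nM.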

Compound 3, half-maximal cytotoxic concentration: 7500 nM
The estimate for compound 3 lay 2.7-fold (0.43 log units) above the measured number; the measured number lies below the stated range.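

Among the compounds shown here, compound 3, with phenyl on this aromatic carbon, is the first compound in this assay to give a number rather than a limit, 7500 nM. Against the two compounds with larger groups at this place, the result is an at least 1.3-fold lower number from compound 2 to compound 3 (0.12 log units; that floor lies within the scatter) and an at least 1.3-fold lower number from compound 1 to compound 3 (0.12 log units; that floor lies within the scatter), so no drop beyond the scatter is established. The true size of both steps stays unknown because of a single ceiling: the limit of > 10000 nM in this assay, at which 2 of the 3 values shown sit.

From the compounds shown here alone, whether an amine or a carboxylic acid at this place would give a number like that of compound 3 or return to the limit remains open.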